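Ester-to-sulfonamide swap on the chain amide of compound 2

The source may hold more compounds than are shown below. What is called first, only, known or untested is meant among the compounds shown, and "the series" means these compounds.

Going by the values given here, compound 2 `COC(=O)CCCNC(=O)CN1CN(c2ccccc2)C2(CCN(C(=O)c3ccc(C4CCCCC4)cc3)CC2)C1=O` gives in an assay on HEK293 cells for displacement of a labelled ligand from NPC1-like intracellular cholesterol transporter 1 (Homo sapiens) (a lower number here means a stronger inhibitor, a higher number a weaker inhibitor), a value of 2500 nM, the highest of the two numbers so far. Its nearest neighbour is compound 1 `CCOC(=O)C1CCN(C(=O)CN2CN(c3ccccc3)C3(CCN(C(=O)c4ccc(C5CCCCC5)cc4)CC3)C2=O)CC1`, which in this assay gives 900 nM; the step of a 2.8-fold higher number from compound 1 to compound 2 (0.44 log units; beyond the scatter) replaces the cyclic ester-bearing amine with the open-chain ester-bearing amine. Compound 3 `CS(=O)(=O)NCCNC(=O)CN1CN(c2ccccc2)C2(CCN(C(=O)c3ccc(C4CCCCC4)cc3)CC2)C1=O` keeps that open chain and changes only its end: methanesulfonamido in place of (methoxycarbonyl)methyl on a saturated chain carbon, two bonds along the chain from an amide-type nitrogen. Among the compounds with values here, no measured step touches this terminal group, so the measured data give no direct guide; the only measured step concerns the amine portion, not the chain terminus, and is modest in size. The working expectation is therefore that compound 3 stays close to compound 2, with a 1.1-fold higher number from compound 2 to compound 3 (0.05 log units; within the scatter) not beyond the scatter. Compound 3 is estimated at 2800 nM in this assay, within a range of 1000 nM to 8000 nM.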

Compound 3, half-maximal inhibitory concentration: 2100 nM
For compound 3 the middle estimate is 1.3-fold (0.12 log units) above the measured one; the measured number falls inside the stated range.
By their numbers in this assay, from the lowest: compound 1; then compounds 3 and 2 (each within the scatter of the next).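

In this assay, the end of the open chain accepts this exchange: methanesulfonamido in place of (methoxycarbonyl)methyl gives a 1.2-fold lower number from compound 2 to compound 3 (0.08 log units; within the scatter), so the ester is not needed at this terminus to hold the level of compound 2, and the added hydrogen-bond donor leaves the reading within the scatter. The gap to the cyclic amine persists with the new terminus, at a 2.3-fold higher number from compound 1 to compound 3 (0.37 log units; beyond the scatter), so it does not depend on the ester end group of the open chain. Nothing at hand accounts for either step.

Open, as far as these compounds go, is whether a carboxylic acid, a primary amine or a longer chain at this terminus would move the number away from compound 2. Also open, from the compounds shown here alone, is whether a methanesulfonamido end group on the cyclic amine would hold the level of compound 1, at 900 nM.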